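Lengthening the amide chain of a threonine-derived cytotoxic amide

The source may report more compounds than this note shows. Statements on the series, on what has been measured and on what is new or still open speak of the compounds shown alone.

Three compounds share one core and differ only in the group on a carbonyl carbon. Compound 1 `CCCCCCCCNC(=O)[C@@H](NC(=O)c1cccs1)[C@@H](C)O` gives 149000 nM in a functional assay on HepG2 cells (Homo sapiens) for cytotoxicity, read by MTT assay, with a stated time of 48 h; a lower number here means a stronger inhibitor, a higher number a weaker inhibitor. Compound 2 `CCCCCCCCNC(=O)[C@@H](NC(=O)c1cc2ccccc2o1)[C@@H](C)O` gives 81300 nM, and compound 3 `CCCCCCCCNC(=O)[C@@H](NC(=O)/C=C/c1ccccc1)[C@@H](C)O` gives 55600 nM, the lowest of the three numbers, though a 1.5-fold lower number from compound 2 to compound 3 (0.17 log units; within the scatter) and only a 2.7-fold lower number from compound 1 to compound 3 (0.43 log units; beyond the scatter).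

Compound 4 `CCCCCCCCCCCCCCNC(=O)[C@@H](NC(=O)/C=C/c1ccccc1)[C@@H](C)O` keeps the acyl group of compound 3 and changes the chain instead: hexyl in place of hydrogen on a saturated chain carbon, eight bonds along the chain from an amide-type nitrogen. Within the data shown here, none of the measured steps touches this chain, so they give no guide to its size or direction; the measured steps, a 1.8-fold lower number from compound 1 to compound 2 (0.26 log units; within the scatter) and a 2.7-fold lower number from compound 1 to compound 3 (0.43 log units; beyond the scatter), concern the acyl group alone. The estimated step is a 1.9-fold lower number from compound 3 to compound 4 (0.27 log units; within the scatter). Compound 4 is expected to give 30000 nM, within 8000 nM to 120000 nM.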

Compound 4, half-maximal inhibitory concentration: 150000 nM
Compound 4: the middle estimate sits 5.0-fold (0.70 log units) below what was measured; the whole stated range lies below it.
By their numbers in this assay, from the lowest: compounds 3, 2, 1 and 4 (each within the scatter of the next, the first and the last beyond it).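

In this assay hexyl in place of hydrogen on a saturated chain carbon, eight bonds along the chain from an amide-type nitrogen, gives a 2.7-fold higher number from compound 3 to compound 4 (0.43 log units; beyond the scatter) and so a weaker compound, a modest change but one beyond the scatter. Among these compounds, the earlier compounds varied only the acyl group, so this is the first sign that the chain itself affects the reading. Nothing available explains this step.

From the compounds shown here alone, whether butyl at this same carbon, or a longer chain still, would give a higher or lower number remains open. So does whether hexyl has the same effect alongside the thiophen-2-yl or 1-benzofuran-2-yl acyl groups.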